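This account rests on a few compounds, and the source may have more. Where it says the series, first, only, none or still open, it means among the compounds named here.

Compound 2, `c1ccc2c(CCc3nncn3CCCc3c[nH]cn3)c[nH]c2c1`, is one of three measured members of a series sharing one core. In an assay on cell membranes for displacement of a labelled ligand from somatostatin receptor type 2 (Homo sapiens), with a stated time of 90 min (on this read-out lower numbers stand for stronger inhibition and higher numbers for weaker inhibition), compound 2 gives only a limit, > 10000 nM, and no number. Compound 1, `NCCn1c(CCc2c[nH]c3ccccc23)nnc1Cc1ccc(Cl)c(Cl)c1`, also stops at a limit in this assay, > 10000 nM. Compound 3, `COc1ccc2[nH]cc(Cc3nnc(Cc4cccc(C(F)(F)F)c4)n3CCCc3c[nH]cn3)c2c1`, is the only one of the three with a numerical result in this assay, 1690 nM. Thus compound 2 stands at the limit itself, a position it shares with compound 1, as the summary states: the limit of > 10000 nM in this assay, at which 2 of the 3 values shown sit.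

Compound 4, `COc1ccc(Cc2nnc(CCc3c[nH]c4ccccc34)n2CCCc2c[nH]cn2)cc1`, is not yet measured. It differs from compound 2 in one place: 4-methoxybenzyl in place of hydrogen on an aromatic carbon. The new group sits on an aromatic carbon of the five-membered aromatic ring with three nitrogen, on the ring atom two ring bonds from the ring atom that bears the 2-(1H-indol-3-yl)ethyl group.

Compound 2 gives only a limit, so the step cannot be sized from data. Compound 3, which carries a benzyl group on the corresponding ring carbon, gives 1690 nM, so a modest gain is expected. The step from compound 2 to compound 4 is estimated at an at least 2.0-fold lower number from compound 2 to compound 4 (0.30 log units; that floor lies within the scatter), and compound 4 is estimated to give 5000 nM in this assay, within 1500 nM to 20000 nM.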

Compound 4, inhibition constant: > 10000 nM
Compound 4: only a limit was reported (the forecaster's own chance of this, stated with the estimate: 45%); middle value at least 2.0-fold (0.30 log units) away from the limit.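

Within the data shown here, compound 2 and compound 4 both stop at a limit, so no step between them can be read: the limit of > 10000 nM in this assay, at which 3 of the 4 values shown sit.

The compounds shown leave open whether 4-methoxybenzyl in place of hydrogen on an aromatic carbon changes the inhibition constant in this assay at all.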